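Trimming the urea side chain of a benzothiazole antiproliferative

The compounds below may be only part of what the source reports. "The series", "measured", "known", "first", "only" and "open" are said of these compounds alone.

Compound 1 `COc1ncc(-c2ccc3nc(NC(=O)NCCN4CCCC4)sc3c2)cc1NS(=O)(=O)c1ccc(F)cc1` is the strongest of the three measured compounds in a functional assay on U-87MG ATCC cells for antiproliferative activity against U-87 MG (Homo sapiens), read by MTT assay, with a stated time of 72 h (a higher number here means a weaker inhibitor, a lower number a stronger inhibitor), where compound 1 gives 360 nM. Compound 2 `COc1ncc(-c2ccc3nc(NC(=O)NCCN(C)C)sc3c2)cc1NS(=O)(=O)c1ccc(F)cc1` gives 1020 nM, and compound 3 `COc1ncc(-c2ccc3nc(NC4CC4)sc3c2)cc1NS(=O)(=O)c1ccc(F)cc1` gives 1500 nM. Compound 4 `CNC(=O)Nc1nc2ccc(-c3cnc(OC)c(NS(=O)(=O)c4ccc(F)cc4)c3)cc2s1` differs from compound 1 by hydrogen in place of (pyrrolidin-1-yl)methyl on a saturated chain carbon bound to an amide-type nitrogen. Among the measured compounds shown here, two measured steps bear on this change: a 2.8-fold higher number from compound 1 to compound 2 (0.45 log units; beyond the scatter), and a 4.2-fold higher number from compound 1 to compound 3 (0.62 log units; beyond the scatter). Both steps weaken the activity in this assay when the pyrrolidin-1-yl end of the chain is altered or the whole (2-(pyrrolidin-1-yl)ethyl)carbamoyl group is exchanged, so a loss of a similar modest size is expected here, a 3.3-fold higher number from compound 1 to compound 4 (0.52 log units; beyond the scatter). Compound 4 is therefore estimated at 1200 nM, with a likely range from 500 nM to 3000 nM.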

Compound 4, half-maximal inhibitory concentration: 1230 nM
For compound 4 the middle estimate is 1.0-fold (0.01 log units) below the measured one; the range from low to high includes it.
By their numbers in this assay, from the lowest: compound 1; then compounds 2, 4 and 3 (each within the scatter of the next).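

Cutting the chain back to methylcarbamoyl (a 3.4-fold higher number from compound 1 to compound 4 (0.53 log units; beyond the scatter)) shows that in this assay the advantage of compound 1 depends on the (pyrrolidin-1-yl)methyl end, since the urea carbonyl kept in compound 4 does not preserve it. The short urea stands level with the dimethylamino chain (a 1.2-fold higher number from compound 2 to compound 4 (0.08 log units; within the scatter)) and with the cyclopropyl compound (a 1.2-fold lower number from compound 3 to compound 4 (0.09 log units; within the scatter)), so neither (dimethylamino)methyl on the chain nor methylcarbamoyl in place of cyclopropyl separates these compounds. Going by these compounds, whether a piperidine or morpholine at the chain end, or a longer chain, would match compound 1 remains open. Nothing shown here explains the role of the (pyrrolidin-1-yl)methyl end.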